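Carbamoyl to ethoxycarbonyl on the shared core

A few compounds are considered here, and "the series" means these few. Any claim that something is new, unique, unknown or untested is made for them only; others in the source may bear on it.

Compound 2 `NC(=O)C1CCN(c2c(S(=O)(=O)c3ccccc3)cnc3ccccc23)CC1` is the point of departure. Among the compounds with values here, in an assay on isolated protein for displacement of a labelled ligand from metabotropic glutamate receptor 5 (Homo sapiens), with a stated time of 60 min, tested at 1 uM (a higher number here means more inhibition at the concentration tested (going by the name of the read-out), a lower number less inhibition), compound 2 gives 24.8%, the second highest of the three numbers known so far. Its nearest neighbour is compound 3 `CN1CCN(c2c(S(=O)(=O)c3ccccc3)cnc3ccccc23)CC1`, which in this assay gives 7.7%, so that a number 17.1 percentage points lower from compound 2 to compound 3 (beyond the scatter). Farthest away stands compound 1 `COc1ccc(S(=O)(=O)c2cnc3ccc(F)cc3c2N2CCC(C)CC2)cc1`, which bears other groups on the shared core and in this assay gives 85%.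

Compound 4 `CCOC(=O)C1CCN(c2c(S(=O)(=O)c3ccccc3)cnc3ccccc23)CC1` has not yet been measured. It differs from compound 2 as follows: ethoxy in place of amino on a carbonyl carbon. Within the data shown here, the one measured step exchanges the whole ring attached to the aromatic carbon; no measured step alters only the group on the carbonyl carbon, so none bears directly on this change. The hydrogen-bond donor of the carbamoyl group is lost, but the two compounds without such a donor lie both lower, as compound 3, and higher, as compound 1, and compound 1 differs in further places besides. With nothing pointing one way, a step of no size beyond the scatter, a number 3.2 percentage points higher from compound 2 to compound 4 (within the scatter), is expected, with a wide band of uncertainty. Compound 4 is therefore estimated to give 28% in this assay, between 8% and 55%.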

Compound 4, a percentage reported as inhibition, at one concentration (the size of the read-out at that concentration, not a potency): 33%
The estimate for compound 4 lay 5 percentage points below the measured number; the range from low to high includes it.
By their numbers in this assay, from the lowest: compound 3; then compounds 2 and 4 (each within the scatter of the next); then compound 1.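

Compound 2 and compound 4 are the first pair shown that differs only in the group on the carbonyl carbon, and in this assay exchanging amino for ethoxy gives a number 8.2 percentage points higher from compound 2 to compound 4 (within the scatter) on the shared core. The change removes the hydrogen-bond donor of the carbamoyl group and brings in the three heavy atoms of ethoxy, yet the read-out does not move beyond the scatter, so in this single pair neither that donor nor the added atoms make a measurable difference. No measurement is available that would explain this result.

The compounds shown leave open whether a carboxylic acid, a methyl ester or an amide carrying a longer chain on its nitrogen would also stay within the scatter of compound 2 when placed on the same saturated ring carbon. They also leave open whether the exchange of carbamoyl for ethoxycarbonyl would read the same on the differently substituted core of compound 1, which gives 85% with a 4-methylpiperidine ring and no carbonyl group there.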